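The source may hold more compounds than are shown below. What is called first, only, known or untested is meant among the compounds shown, and "the series" means these compounds.

Working notes on the series, as read in a functional assay on the whole organism with Mus musculus as the target; on this read-out higher numbers stand for an effect only at larger amounts of compound and lower numbers for an effect already at smaller amounts. Compound 1 `NC(=O)/C=C1\CCc2c(F)cccc21` gives > 100 mg/kg, which is a limit of the assay and not a number. Compound 2 `O=C(/C=C1\CCc2ccccc21)NC1CC1` gives 150 mg/kg. Within the data shown here, compound 3 `O=C(/C=C1\CCc2c(F)cc(F)cc21)NC1CC1` gives 62 mg/kg, the lower of the only two true numbers so far, and its gap to compound 2 lies beyond the usual scatter.

The next compound to be read is compound 4 `O=C(/C=C1\CCc2c(F)cccc21)NC1CC1`. It differs from compound 3 in one place: hydrogen in place of fluoro on an aromatic carbon. Hydrogen stands in place of fluoro on an aromatic carbon, meta to a fluoro group and para to a fused ring.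

Among the measured compounds shown here, no measured pair differs in one place only, so no measured step can be carried over and the expectation rests on the values alone. The number for compound 4 is expected to rise from that of compound 3 and to stay under that of compound 2, which gives 150 mg/kg. The estimated change is modest, a 1.5-fold higher number from compound 3 to compound 4 (0.19 log units; within the scatter), and is not expected to stand clearly beyond the scatter. In this assay, the expected value for compound 4 is 95 mg/kg, with an estimated range of 50 mg/kg to 170 mg/kg.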

Compound 4, dose for half-maximal effect: 126 mg/kg
The estimate for compound 4 lay 1.3-fold (0.12 log units) below the measured number; the measured number falls inside the stated range.
By their numbers in this assay, from the lowest: compound 3; then compounds 4 and 2 (each within the scatter of the next).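

In this assay, among these compounds, hydrogen in place of fluoro on this aromatic carbon, meta to a fluoro group and para to a fused ring, gives a 2.0-fold higher number from compound 3 to compound 4 (0.31 log units; beyond the scatter) as the only readable step at this position, so the change is modest but does lie beyond the scatter. The other single change, fluoro in place of hydrogen on an aromatic carbon, gives a 1.2-fold lower number from compound 2 to compound 4 (0.08 log units; within the scatter) and leaves no change that can be told from the scatter, which places the lower number of compound 3 with the fluoro at the position para to a fused ring, present there together with the other fluoro. Compound 1 stands at a limit of the assay and not at a number, and its step to compound 4, cyclopropyl in place of hydrogen on an amide-type nitrogen, cannot be read: the limit of > 100 mg/kg in this assay, at which 1 of the 4 values shown sits.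

On these data alone, whether chloro, methoxy or a nitrile on this aromatic carbon would hold the number of compound 3 or move it stays open. Also open, as far as these compounds go, is whether fluoro at this position would give a step of the same size on the shared core without the other fluoro.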